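A few compounds are considered here, and "the series" means these few. Any claim that something is new, unique, unknown or untested is made for them only; others in the source may bear on it.

Going by the values given here, compound 2 `COc1cc(C=O)cc2c1CC(C)(C)O2` is the one compound here with an actual number: in a functional assay on the whole organism with Homo sapiens as the target, read by hemolysis (on this read-out higher numbers stand for weaker inhibition and lower numbers for stronger inhibition), compound 2 gives 1100000 nM. Compound 1 `CC1(C)Cc2c(O)cc(C=O)cc2O1` reaches only a limit of the assay, > 1560000 nM, in this assay. Among the compounds with values here, the single measured step, an at least 1.4-fold lower number from compound 1 to compound 2 (0.15 log units; that floor lies within the scatter), concerns a methyl on an oxygen and does not touch the change ahead. Compound 3 `COc1cc(-c2nn[nH]n2)cc2c1CC(C)(C)O2` differs from compound 2 by 2H-tetrazol-5-yl in place of formyl on an aromatic carbon. Within the data shown here, no measured step bears on that swap, so for compound 3 the expected step of a 1.4-fold higher number from compound 2 to compound 3 (0.13 log units; within the scatter) is set close to none, with wide uncertainty. The estimate for compound 3 in this assay is 1500000 nM, within 400000 nM to 6000000 nM.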

Compound 3, half-maximal inhibitory concentration: 245000 nM
Beside the measured number, compound 3's estimate is 6.1-fold (0.79 log units) above it, and the stated range ends above it.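

In this assay, 2H-tetrazol-5-yl in place of formyl on this aromatic carbon gives a 4.5-fold lower number from compound 2 to compound 3 (0.65 log units; beyond the scatter), a modest step but the only one shown that is clearly beyond the scatter. It shows that the number responds to the group on this carbon, which the methyl on the oxygen could not show. Nothing given here explains why this swap lowers the number. On these data alone, whether a carboxylic acid or an amine on the same carbon would lower it as well remains open, as does whether the step holds with hydroxy in place of the methoxy group.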